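The compounds below may be only part of what the source reports. "The series", "measured", "known", "first", "only" and "open" are said of these compounds alone.

Compounds 1, 2 and 3 share one core and differ at the aryl end of the chain. Compound 1 `CCCc1nc(-c2ccccc2)c(CNCCCN2CCN(c3ccccc3OC)CC2)o1` gives 41% in an assay on HEK293 cells for inhibition of Voltage-dependent T-type calcium channel subunit alpha-1G (Homo sapiens), read by fluorescence, tested at 10 uM (on this read-out lower numbers stand for less inhibition and higher numbers for more inhibition at the one concentration tested (going by the name of the read-out)), the lowest of the three numbers. Compound 2 `CCCc1nc(-c2ccccc2)c(CNCCN2CCN(c3ccc(C)cc3)CC2)o1` gives 48.1% in this assay, a gap within the scatter, while compound 3 `CCCc1nc(-c2ccccc2)c(CNCCN2CCN(c3ccc(Cl)cc3)CC2)o1` gives 55.8% in this assay, a gap beyond it. Among the compounds with values here, the only measured step, a number 7.7 percentage points higher from compound 2 to compound 3 (within the scatter), exchanges chloro for methyl on an aromatic carbon and stays within the scatter. Compound 4 `CCCc1nc(-c2ccccc2)c(CNCCCN2CCN(c3ccccc3C(F)(F)F)CC2)o1` differs from compound 1 by trifluoromethyl in place of methoxy on an aromatic carbon. Within the data shown here, no measured step covers this exchange, and the one step that exists stayed within the scatter, so the expected step is small, a number 6 percentage points higher from compound 1 to compound 4 (within the scatter). Compound 4 is therefore estimated at 47%, between 30% and 64%.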

Compound 4, a percentage reported as inhibition, at one concentration (the size of the read-out at that concentration, not a potency): 45%
Compound 4: middle estimate off by 2 percentage points, on the high side, and the stated range covers the measured number.
By their numbers in this assay, from the lowest: compounds 1, 4, 2 and 3 (each within the scatter of the next, the first and the last beyond it).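

Trifluoromethyl in place of methoxy, on an aromatic carbon ortho to a large group, gives a number 4 percentage points higher from compound 1 to compound 4 (within the scatter). This exchange removes the hydrogen-bond acceptor of the methoxy, yet the step stays within the scatter, so for this pair the read-out does not depend on that acceptor. No measurement shown gives a reason for this result. Going by these compounds, it remains open whether a hydroxyl or an amine at this same place would move the number beyond the scatter. On these data alone, a longer chain to the piperazine nitrogen also remains open.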